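Replacing one all-carbon ring group with cyclohexyl

The source may report more compounds than this note shows. Statements on the series, on what has been measured and on what is new or still open speak of the compounds shown alone.

Compound 1 `Cc1ccc(CNCc2cc(C)n(-c3ccc(Cl)cc3)c2C)cc1`: 6.1 ug/mL
Compound 2 `Cc1cc(CN2CCN(C3C[C@@H]4CC[C@H]3C4)CC2)c(C)n1-c1ccc(Cl)cc1`: 16 ug/mL

In an ADME assay on THP-1 cells (Homo sapiens) for cytotoxicity, read by trypan blue exclusion, with a stated time of 48 h (on this read-out higher numbers stand for weaker inhibition of growth and lower numbers for stronger inhibition of growth), compound 2 gives 16 ug/mL, the highest of the two numbers, and the gap down to compound 1 lies beyond the scatter. Compound 3 `Cc1cc(CN2CCN(C3CCCCC3)CC2)c(C)n1-c1ccc(Cl)cc1` changes one place of compound 2, on an amine nitrogen in a ring: a group of 6 heavy atoms (6 carbon; one six-membered non-aromatic ring of carbon only) in place of a group of 7 heavy atoms (7 carbon; 2 five-membered non-aromatic rings of carbon only), on an amine nitrogen in a ring. For the measured compounds named here, no measured pair shows this change, so the guide is thin. In this assay, compound 2 serves as the reference at 16 ug/mL. Compound 3 is expected to stay within the scatter of that value. The expected step is a 1.1-fold lower number from compound 2 to compound 3 (0.06 log units; within the scatter). For compound 3 the estimated value is 14 ug/mL, with an expected range from 7 ug/mL to 28 ug/mL.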

Compound 3, concentration for 50% growth inhibition: 16 ug/mL
Beside the measured number, compound 3's estimate is 1.1-fold (0.06 log units) below it; the range from low to high includes it.
By their numbers in this assay, from the lowest: compound 1; then compounds 2 and 3 (each within the scatter of the next).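

In this assay, putting cyclohexyl in place of the group with two five-membered carbon rings, on the amine nitrogen in a ring, gives no change at the digits printed from compound 2 to compound 3 (within the scatter). At this position, then, the two all-carbon ring groups read alike, even though only the group that leaves has 2 defined stereocentres. Nothing available explains this likeness. The compounds shown leave open whether a much smaller group, such as methyl, or a flat aromatic group, such as phenyl, would also read alike on this nitrogen.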